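Swapping a Methoxy for a Hydroxy on Compound 3

The source may hold more compounds than are shown below. What is called first, only, known or untested is meant among the compounds shown, and "the series" means these compounds.

Among the compounds with values here, in a functional assay on LNCaP cells (Homo sapiens) for cytotoxicity, read by MTT assay, with a stated time of 72 h (on this read-out lower numbers stand for stronger inhibition and higher numbers for weaker inhibition), compound 3 `COc1cc(/C=C/C(O)=C/C(=O)/C=C/C2=C(C)CCCC2(C)C)cc(OC)c1OC` gives 21400 nM, the highest of the three numbers measured so far. Compound 2 `COc1cc(/C=C/C(O)=C/C(=O)/C=C/C2=C(C)CCCC2(C)C)ccc1O`, at 20600 nM, lies within the usual scatter of compound 3. Compound 1 `COc1cc(/C=C/C(=O)/C(=C/c2ccc3ccccc3n2)C(=O)/C=C/C2=C(C)CCCC2(C)C)ccc1O`, at 8500 nM, has a lower number than compound 3, and that gap lies beyond the scatter.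

Compound 4 `COc1cc(/C=C/C(O)=C/C(=O)/C=C/C2=C(C)CCCC2(C)C)cc(OC)c1O` carries one change from compound 3: hydrogen in place of methyl on an oxygen on an aromatic ring, or methoxy to hydroxy (hydrogen in place of methyl on an oxygen on an aromatic ring). Within the data shown here, no measured pair shows this change alone, so its size cannot be read directly. Compound 2 also carries a hydroxy on its aromatic ring, and at 20600 nM it stays within the scatter of compound 3. No step beyond the scatter is therefore expected in this assay. The expected result is a 1.3-fold lower number from compound 3 to compound 4 (0.10 log units; within the scatter), a small move towards a lower number. Compound 4 is estimated at 17000 nM, with an expected range of 8000 nM to 36000 nM.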

Compound 4, half-maximal inhibitory concentration: 6200 nM
Estimate against measurement, compound 4: 2.7-fold (0.44 log units) above; measured number outside the range, below it.
By their numbers in this assay, from the lowest: compounds 4 and 1 (each within the scatter of the next); then compounds 2 and 3 (each within the scatter of the next).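

In this assay, within the data shown here, hydrogen in place of methyl on an oxygen on an aromatic ring gives a 3.5-fold lower number from compound 3 to compound 4 (0.54 log units; beyond the scatter) and so shows that a change at this oxygen can move the number beyond the scatter, which the earlier compounds could not show. Methoxy in place of hydrogen on an aromatic carbon gives a 3.3-fold lower number from compound 2 to compound 4 (0.52 log units; beyond the scatter) in the same direction, so compound 4 stands apart from both of its single-change neighbours: taking away either the methyl or the methoxy brings the number back up. Nothing measured here explains why this one combination of groups gives the lower number.

The compounds shown leave open whether the free hydroxy is needed, as an ethoxy or an amine at that place is not among them. They also leave open whether a chlorine could stand in for the added methoxy on the aromatic carbon.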